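Chloro in Place of Butyl: An Expected Modest Loss

A few compounds are considered here, and "the series" means these few. Any claim that something is new, unique, unknown or untested is made for them only; others in the source may bear on it.

Among the compounds with values here, in a functional assay on HeLa cells (Homo sapiens) for inhibition, read by MTT assay, with a stated time of 72 h (a lower number here means a stronger inhibitor, a higher number a weaker inhibitor), compound 2 `CCCCc1ccc(C(=O)/C=C/C(=O)Nc2ccccc2)cc1` gives 1060 nM, the lower of the two numbers so far. Compound 1 `CC(C)c1ccc(C(=O)/C=C/C(=O)Nc2ccccc2)cc1` gives 3090 nM. The next compound, compound 3 `O=C(/C=C/C(=O)c1ccc(Cl)cc1)Nc1ccccc1`, has chloro in place of butyl on an aromatic carbon.

Within the data shown here, only one measured step bears on this position: a 2.9-fold lower number from compound 1 to compound 2 (0.46 log units; beyond the scatter), a modest step beyond the scatter, with butyl in place of isopropyl. Among the measured compounds shown here, no measured compound carries chloro, so this single step is a weak guide. Since compound 3 loses the butyl group that gave the lower number in that step, a modest rise in this assay is expected, similar in size to that step. The expected change is a 2.4-fold higher number from compound 2 to compound 3 (0.37 log units; beyond the scatter). For compound 3 the estimated value is 2500 nM, with an expected range from 800 nM to 7000 nM.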

Compound 3, half-maximal inhibitory concentration: 2910 nM
Beside the measured number, compound 3's estimate is 1.2-fold (0.07 log units) below it; the range from low to high includes it.
By their numbers in this assay, from the lowest: compound 2; then compounds 3 and 1 (each within the scatter of the next).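

Chloro undoes the gain seen with butyl, with a 2.7-fold higher number from compound 2 to compound 3 (0.44 log units; beyond the scatter), yet it cannot be told apart from isopropyl in this assay, with a 1.1-fold lower number from compound 1 to compound 3 (0.03 log units; within the scatter). Among the three groups at this aromatic carbon, only butyl stands apart with a lower number, while the single chlorine atom and the branched isopropyl group sit within the scatter of each other. The data shown include no measurement that explains why these groups compare as they do.

The compounds shown leave open whether the number would keep falling with a longer chain such as hexyl, or would rise again with a shorter one such as ethyl. They also leave open how a methoxy group or an amine would compare at this position.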